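This account rests on a few compounds, and the source may have more. Where it says the series, first, only, none or still open, it means among the compounds named here.

In a functional assay (plasma) with Oryctolagus cuniculus as the target (a lower number here means a stronger inhibitor, a higher number a weaker inhibitor), compound 1 `CCCC(CC(=O)N1CCC(Cn2c(C)nc3cnccc32)CC1)c1ccccc1` gives 11 nM and compound 2 `COc1ccccc1CCC(=O)N1CCC(Cn2c(C)nc3cnccc32)CC1` gives 15 nM as its measured value. These two numbers lie within the scatter of repeated measurements, so compound 2 stands level with compound 1 on the data so far. Compound 3 `COc1ccccc1N(C)CC(=O)N1CCC(Cn2c(C)nc3cnccc32)CC1` has not yet been measured. It differs from compound 2 on a saturated chain carbon bound to a carbonyl carbon, where (2-methoxyphenyl)(methyl)amino stands in place of 2-methoxybenzyl ((2-methoxyphenyl)(methyl)amino in place of 2-methoxybenzyl on a saturated chain carbon bound to a carbonyl carbon) in a single exchange of groups. Within the data shown here, one measured step bears on this change: a 1.4-fold higher number from compound 1 to compound 2 (0.13 log units; within the scatter) with 2-methoxybenzyl in place of 1-phenylbutyl at that same carbon. Among the measured compounds shown here, the one exchange seen there thus moved the number no further than the scatter. For the measured compounds named here, no measured compound carries the entering group, so this evidence is thin and the range must stay wide. No shift beyond the scatter is expected, and the estimated step is a 1.2-fold higher number from compound 2 to compound 3 (0.08 log units; within the scatter) in this reading. For compound 3 the estimated value is 18 nM with an expected range from 5 nM to 60 nM in this assay.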

Compound 3, half-maximal inhibitory concentration: 14 nM
For compound 3 the middle estimate is 1.3-fold (0.11 log units) above the measured one, and the stated range covers the measured number.
By their numbers in this assay, from the lowest: compounds 1, 3 and 2 (each within the scatter of the next).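

In this assay, the exchange of 2-methoxybenzyl for (2-methoxyphenyl)(methyl)amino on a saturated chain carbon bound to a carbonyl carbon gives a 1.1-fold lower number from compound 2 to compound 3 (0.03 log units; within the scatter) and so leaves the number level. This is new in kind: the entering group brings a nitrogen and a second hydrogen-bond acceptor by the computed count, yet the aromatic ring of carbon and the methoxy group stay, and the reading does not leave the scatter. Set against the 1-phenylbutyl group, the same exchange gives a 1.3-fold higher number from compound 1 to compound 3 (0.10 log units; within the scatter), so all three groups seen at this carbon now stand level with one another, where the earlier pair offered only a single comparison. No other measurement is available that would explain why these numbers stay together.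

All three groups shown carry an aromatic ring, so it remains open whether this position stays as undemanding once that ring is gone, as with a carboxylic acid or a simple primary amine in its place. As far as these compounds go, it is equally open how a longer chain between the carbonyl and the ring would read, since every step seen so far lies within the scatter.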